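The source may report more compounds than this note shows. Statements on the series, on what has been measured and on what is new or still open speak of the compounds shown alone.

Measured in a functional assay on NCI-H460 cells (Homo sapiens) for antiproliferative activity, read by MTT assay, with a stated time of 48 h; a lower number here means a stronger inhibitor, a higher number a weaker inhibitor:
Compound 1 `COc1ccc(Nc2ccc3c(c2)C(O)(Cc2ccccc2)C(=O)N3)cc1`: > 100000 nM, a limit and not a number
Compound 2 `CCCCC1(O)C(=O)Nc2ccc(Nc3ccc(F)cc3)cc21`: 32500 nM
Compound 3 `CCCCCCC1(O)C(=O)Nc2ccc(Nc3ccc(F)cc3)cc21`: 50700 nM

Among the compounds with values here, compound 3, at 50700 nM, stands level with compound 2, as the only measured step, a 1.6-fold higher number from compound 2 to compound 3 (0.19 log units; within the scatter), lies within the scatter. Compound 4 `O=C1Nc2ccc(Nc3ccc(F)cc3)cc2C1(O)Cc1ccccc1` changes the chain of compound 3: phenyl in place of pentyl on a saturated chain carbon bound to a saturated ring carbon. In words, this is phenyl in place of pentyl on a saturated chain carbon bound to a saturated ring carbon, or hexyl to benzyl. The measured step added ethyl and brought a ring into nothing, so it offers only a weak guide. Compound 1 also carries benzyl, on a core with a different other group, and its > 100000 nM is a limit. The expected change is a 1.2-fold higher number from compound 3 to compound 4 (0.07 log units; within the scatter), with no shift beyond the scatter. For compound 4 the estimate is 60000 nM, with an expected range of 20000 nM to 100000 nM.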

Compound 4, half-maximal inhibitory concentration: 18100 nM
Beside the measured number, compound 4's estimate is 3.3-fold (0.52 log units) above it, and the stated range ends above it.
By their numbers in this assay, from the lowest: compounds 4, 2 and 3 (each within the scatter of the next, the first and the last beyond it). At a limit, above all of these: compound 1.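

In this assay, phenyl in place of pentyl on this saturated chain carbon gives a 2.8-fold lower number from compound 3 to compound 4 (0.45 log units; beyond the scatter) and so shows that a ring here can beat the longest chain. Phenyl in place of propyl gives a 1.8-fold lower number from compound 2 to compound 4 (0.25 log units; within the scatter) and so separates compound 4 less clearly from the shorter chain. With benzyl held fixed, fluoro in place of methoxy on an aromatic carbon gives an at least 5.5-fold lower number from compound 1 to compound 4 (0.74 log units; beyond the scatter) as a step that rests on compound 1's limit, which is not a number: the limit of > 100000 nM in this assay, at which 1 of the 4 values shown sits.

Still open, going by these compounds, is how other groups at this carbon would behave, such as an amine or a carboxylic acid at the end of the chain.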